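The compounds below may be only part of what the source reports. "The series", "measured", "known", "first", "only" and "open" are said of these compounds alone.

Measured so far:
- compound 1, `Cc1ccc(Nc2c(NCCCCCC(=O)NO)c(=O)c2=O)cc1`: 7.2 uL/min
- compound 2, `CC(CCCCC(=O)NO)Nc1c(Nc2ccccc2)c(=O)c1=O`: < 5 uL/min

Among the measured compounds shown here, the two measured compounds share a core and differ in two places at once, so no single step between them is available. In an ADME assay on cells (Hepatocyte, Homo sapiens) for pharmacokinetics, read by LC-MS, with a stated time of 90 min, tested at 1 uM (a lower number here means slower removal, a higher number faster removal of the compound), compound 1 gives 7.2 uL/min. Compound 2 reaches only a limit in this assay, < 5 uL/min, and no number behind that limit is known; this is the limit of < 5 uL/min in this assay, at which 1 of the 2 values shown sits. Compound 3, `Cc1ccc(Nc2c(NC(C)CCCCC(=O)NO)c(=O)c2=O)cc1`, is compound 2 with a methyl in place of hydrogen on an aromatic carbon. With only a limit as the starting point, the step from compound 2 to compound 3 in this assay cannot be placed beyond the scatter in either direction, and none beyond the scatter is expected, an at least 1.2-fold higher number from compound 2 to compound 3 (0.07 log units; that floor lies within the scatter). Compound 3 is expected to give about 6 uL/min in this assay, somewhere between 3 uL/min and 12 uL/min, with a fair chance that the assay again reports only a limit.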

Compound 3, intrinsic clearance in a liver preparation (reported as CLH), per the amount of preparation that the assay uses: < 6.5 uL/min
Compound 3: a limit, no number; the forecaster's own chance of this, stated with the estimate: 40%; the middle value does not contradict the limit.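

In this assay, compound 3 again gives only a limit, so phenyl to 4-methylphenyl has no readable size, and the step from compound 2 cannot be read: the limit of < 6.5 uL/min in this assay, at which 1 of the 3 values shown sits. With the 4-methylphenyl group kept, the methyl on the saturated chain carbon bound to a nitrogen comes with an at least 1.1-fold lower number from compound 1 to compound 3 (0.04 log units; that floor lies within the scatter). Among the compounds shown here, the only number among the three compounds now belongs to compound 1, the one compound without that chain methyl.

Going by these compounds, how far compound 2 and compound 3 lie under their limits stays open, and with it whether the chain methyl changes removal beyond the scatter at all. Also open, on these data alone, is how a chlorine or a methoxy group in place of the methyl on the aromatic carbon, or a longer chain, would read in this assay.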